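Swapping propyl for propargyl on the sulfur

The compounds below may be only part of what the source reports. "The series", "measured", "known", "first", "only" and "open" are said of these compounds alone.

In a functional assay on MGC-803 cells (Homo sapiens) for antiproliferative activity, read by MTT assay, with a stated time of 72 h (a lower number here means a stronger inhibitor, a higher number a weaker inhibitor), compound 2 `CCCSc1nc(N/N=C/c2c(O)ccc3ccccc23)c2nnn(Cc3ccccc3)c2n1` gives 3710 nM, the lowest of the two numbers measured here. Compound 1 `C#CCSc1nc(N/N=C/c2ccc(N(C)C)cc2)c2nnn(Cc3ccccc3)c2n1` gives 7620 nM in this assay. Compound 3 `CCCSc1nc(N/N=C/c2ccccc2)c2nnn(Cc3ccccc3)c2n1` reaches only > 64000 nM in this assay, which is a limit of the assay and not a number. The step of an at least 17-fold higher number from compound 2 to compound 3 (1.23 log units; beyond the scatter) is large, and its size rests on a value that sits at the limit (the limit of > 64000 nM in this assay, at which 1 of the 3 values shown sits). Compound 4 `C#CCSc1nc(N/N=C/c2c(O)ccc3ccccc23)c2nnn(Cc3ccccc3)c2n1` differs from compound 2 by ethynyl in place of ethyl on a saturated chain carbon bound to a sulfur. Going by the values given here, no measured step touches this position: the one measured step alters the group on the carbon with a double bond to nitrogen, and compound 1, which already carries the propargylsulfanyl group, differs from compound 2 in that group as well, so its value offers no clean comparison. With nothing pointing to a shift, compound 4 is expected to give 3500 nM, with a range from 1500 nM to 9000 nM. The expected step of a 1.1-fold lower number from compound 2 to compound 4 (0.03 log units; within the scatter) thus stays within the scatter.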

Compound 4, half-maximal inhibitory concentration: 10500 nM
Compound 4: middle estimate off by 3.0-fold (0.48 log units), on the low side; measured number outside the range, above it.
By their numbers in this assay, from the lowest: compound 2; then compounds 1 and 4 (each within the scatter of the next). At a limit, above all of these: compound 3.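

Propargyl in place of propyl on the sulfur gives a 2.8-fold higher number from compound 2 to compound 4 (0.45 log units; beyond the scatter) in this assay and is the first clean reading of this position: with the 2-hydroxynaphthalen-1-yl group held fixed, the sulfur chain alone moves the number by a modest amount. With the propargylsulfanyl group held fixed, 2-hydroxynaphthalen-1-yl in place of 4-(dimethylamino)phenyl gives a 1.4-fold higher number from compound 1 to compound 4 (0.14 log units; within the scatter) and leaves these two groups indistinguishable on this chain. Nothing given here explains why the triple bond costs activity.

As far as these compounds go, whether a longer chain such as butyl, or a chain ending in an amine or a carboxylic acid, would do better or worse on the sulfur remains open. So does whether the swap from propyl to propargyl has the same effect when the 4-(dimethylamino)phenyl group is present.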